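Furan-2-yl in place of 2,4-dichlorophenyl

The source may report more compounds than this note shows. Statements on the series, on what has been measured and on what is new or still open speak of the compounds shown alone.

In a functional assay on SMMC-7721 cells (Homo sapiens) for cytotoxicity, read by MTT assay, with a stated time of 72 h (a higher number here means a weaker inhibitor, a lower number a stronger inhibitor), compound 1 (`O=C1C(=Cc2ccc(Cl)cc2)C(=O)N(c2ccc(Cl)cc2)N1c1ccc(Cl)cc1`) gives 30900 nM. Compound 2 (`O=C1C(=Cc2ccc(Cl)cc2Cl)C(=O)N(c2ccc(Cl)cc2)N1c1ccc(Cl)cc1`) stands at > 128000 nM, which is a limit of the assay and not a number; this is the limit of > 128000 nM in this assay, at which 1 of the 2 values shown sits.

Compound 3 (`O=C1C(=Cc2ccco2)C(=O)N(c2ccc(Cl)cc2)N1c1ccc(Cl)cc1`) carries furan-2-yl in place of 2,4-dichlorophenyl on a double-bonded chain carbon bound to a double-bonded ring carbon.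

Among the measured compounds shown here, the one measured step that bears on this is an at least 4.1-fold higher number from compound 1 to compound 2 (0.61 log units; beyond the scatter), with chloro in place of hydrogen on an aromatic carbon of the group that now leaves. For the measured compounds named here, no furan-2-yl compound has been measured, so the guide is weak. A move towards a lower number in this assay is expected, back towards compound 1 at 30900 nM. The expected step is an at least 3.2-fold lower number from compound 2 to compound 3 (0.50 log units; beyond the scatter). For compound 3 the estimated value is 40000 nM, with an expected range of 12000 nM to 120000 nM.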

Compound 3, half-maximal inhibitory concentration: 19500 nM
For compound 3 the middle estimate is 2.1-fold (0.31 log units) above the measured one; low and high end bracket the measured number.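

Furan-2-yl in place of 2,4-dichlorophenyl on a double-bonded chain carbon bound to a double-bonded ring carbon gives an at least 6.5-fold lower number from compound 2 to compound 3 (0.81 log units; beyond the scatter) in this assay, so this position is not restricted to a six-membered aromatic ring of carbon only. The figure for compound 2 is a limit of the assay and not a number: the limit of > 128000 nM in this assay, at which 1 of the 3 values shown sits. Furan-2-yl in place of 4-chlorophenyl at the same position leaves the read-out level, with a 1.6-fold lower number from compound 1 to compound 3 (0.20 log units; within the scatter), so here the smaller ring with its hetero atom matches the monochlorinated ring.

As far as these compounds go, what an amine or a carboxylic acid on the furan-2-yl ring would do at this position remains open, as does the effect of a pyridine ring there. From the compounds shown here alone, the rest of the shared core is the same in all three compounds, so its contribution also remains open.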